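The compounds below may be only part of what the source reports. "The series", "measured", "known", "first", "only" and "open" are said of these compounds alone.

Compound 1, `CC(=O)c1cc(-c2ccccc2)cc2cc(-c3ccccc3)[nH]c12`, gives 65.8% in a functional assay on HeLa cells (Homo sapiens) for cytotoxicity, read by MTT assay, with a stated time of 2 days, tested at 1 uM; on this read-out lower numbers stand for a stronger effect and higher numbers for a weaker effect at the one concentration tested. Compound 2, `COc1ccc(-c2cc3cc(-c4ccccc4)cc(C(C)=O)c3[nH]2)cc1`, gives 61.5% in this assay. Going by the values given here, these two numbers sit within the usual scatter of each other, so no ranking between them can be claimed: the step of a number 4.3 percentage points lower from compound 1 to compound 2 (within the scatter) is the only measured step and it lies within the scatter. This is where compound 2 stands among the two compounds measured.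

Compound 3 is `COc1ccc(-c2cc(C(C)=O)c3[nH]c(-c4ccc(OC)cc4)cc3c2)cc1`. It differs from compound 2 by methoxy in place of hydrogen on an aromatic carbon, the second of the two phenyl groups on the shared core now carrying the same methoxy as the first. Among the compounds with values here, the one measured step that bears on this change is the same change made on the other phenyl group, a number 4.3 percentage points lower from compound 1 to compound 2 (within the scatter), which was within the scatter. On that basis the step of a number 3.5 percentage points lower from compound 2 to compound 3 (within the scatter) is expected to be small, with no direction beyond the scatter that can be stated. Compound 3 is therefore estimated to give 58% in this assay, within a range from 44% to 72%.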

Compound 3, a percentage reported as activity, at one concentration (the size of the read-out at that concentration, not a potency): 60.2%
For compound 3 the middle estimate is 2.2 percentage points below the measured one, and the stated range covers the measured number.
By their numbers in this assay, from the lowest: compounds 3, 2 and 1 (each within the scatter of the next).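

Placed on the second phenyl group, para to a large group, the change from phenyl to 4-methoxyphenyl gives in this assay a number 1.3 percentage points lower from compound 2 to compound 3 (within the scatter) and so leaves compound 2 and compound 3 within the scatter of each other. The same replacement has now been read on both phenyl groups of the shared core, the earlier reading being a number 4.3 percentage points lower from compound 1 to compound 2 (within the scatter), and at this one concentration neither step separates its pair of compounds, so a single methoxy at either place gives no distinction that this read-out can resolve. Nothing available accounts for this result in terms of any property of the group or of the cells.

What the compounds shown leave open is whether a different group at this para place on the phenyl rings, such as an amine, a carboxylic acid or a longer chain such as butoxy, would produce a step beyond the scatter. They also leave open how the acetyl group and the amide hydrogen of the shared core bear on the read-out, and whether compound 2 and compound 3 would stay this close at other concentrations.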